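The source may report more compounds than this note shows. Statements on the series, on what has been measured and on what is new or still open speak of the compounds shown alone.

Series notes on plasma protein binding. In an ADME assay on a cell-free system (plasma, Rattus norvegicus) for protein binding, compound 2 `O=S(=O)(Nc1ncccn1)c1ccc2c(c1)OCC[C@@H]2c1ccc(C(F)(F)F)cc1-c1ccc(F)nc1` gives 93.4%, the higher unbound fraction of the two measured values. Among the measured compounds shown here, compound 1 `Cn1nccc1-c1cc(C(F)(F)F)ccc1[C@H]1CCc2cc(S(=O)(=O)Nc3ncccn3)ccc21` gives 99.3% in this assay, a lower unbound fraction than compound 2, and the gap lies beyond the scatter; the two compounds differ in more than one place, so no single step is counted between them. Compound 3 `Cn1nccc1-c1cc(C(F)(F)F)ccc1[C@H]1CCOc2cc(S(=O)(=O)Nc3ncccn3)ccc21` is not yet measured in this assay. Relative to compound 2 it carries 1-methyl-1H-pyrazol-5-yl in place of 6-fluoropyridin-3-yl on an aromatic carbon. The same aromatic group sits on compound 1, and in this assay compound 1 gives 99.3%, which lies toward the higher-binding end. A moderate rise in bound percentage is expected, a 2.2-fold lower unbound fraction from compound 2 to compound 3 (0.34 log units; beyond the scatter). Compound 3 is estimated at 97%, with a range from 92% to 99.2%.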

Compound 3, plasma protein binding: 91%
Beside the measured number, compound 3's estimate is 3.0-fold (0.48 log units) (unbound fraction) below it; measured number outside the range, below it.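

At this position, on an aromatic carbon ortho to a large group, 1-methyl-1H-pyrazol-5-yl in place of 6-fluoropyridin-3-yl gives a 1.4-fold higher unbound fraction from compound 2 to compound 3 (0.13 log units; within the scatter) in this assay, so the two groups are not told apart here. The same 1-methyl-1H-pyrazol-5-yl group stands on compound 1, which gives 99.3% on its own core, so this group does not bring that value with it onto the core of compound 3. No measurement on hand explains this result. Going by these compounds, whether an amine or a carboxylic acid at this position would shift binding beyond the scatter remains open.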